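A Phenyl Group on the Shared Core of Compound 1

A few compounds are considered here, and "the series" means these few. Any claim that something is new, unique, unknown or untested is made for them only; others in the source may bear on it.

Compound 1 `O=C(CCCCC1CCSS1)NCc1cn(CCCOc2ccc3ccc(=O)oc3c2)nn1`: 37.2%
Compound 2 `CCOC(=O)c1cc2ccc(OCCCn3cc(CNC(=O)CCCCC4CCSS4)nn3)cc2oc1=O`: 28.3%
Compound 3 `O=C(CCCCC1CCSS1)NCc1cn(CCCOc2ccc3cc(C(=O)O)c(=O)oc3c2)nn1`: 52.1%

All three were tested in a functional assay on PC-12 cells (Rattus norvegicus) for cytotoxicity, read by MTT assay, with stated times of 3 h and 2 h, tested at 1 uM; a higher number here means a stronger effect of the compound at the concentration tested, a lower number a weaker effect. Compound 1 stands second highest of the three numbers. The measured steps are a number 8.9 percentage points lower from compound 1 to compound 2 (within the scatter), a number 14.9 percentage points higher from compound 1 to compound 3 (beyond the scatter) and a number 23.8 percentage points higher from compound 2 to compound 3 (beyond the scatter). Compound 4 `O=C(CCCCC1CCSS1)NCc1cn(CCCOc2ccc3cc(-c4ccccc4)c(=O)oc3c2)nn1` differs from compound 1 by phenyl in place of hydrogen on an aromatic carbon. The two steps from compound 1 concern groups entering at this same aromatic carbon, though neither is phenyl; one lay within the scatter and the other was modest. Compound 4 is therefore expected to differ little from compound 1, with an estimated step of a number 0.8 percentage points higher from compound 1 to compound 4 (within the scatter). For compound 4 in this assay the estimate is 38%, expected to fall between 22% and 54%.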

Compound 4, a percentage reported as activity, at one concentration (the size of the read-out at that concentration, not a potency): 31.9%
Beside the measured number, compound 4's estimate is 6.1 percentage points above it, within the range that was stated.
By their numbers in this assay, from the lowest: compounds 2, 4 and 1 (each within the scatter of the next); then compound 3.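

In this assay, phenyl at this aromatic carbon stays within the scatter of both hydrogen (a number 5.3 percentage points lower from compound 1 to compound 4 (within the scatter)) and ethoxycarbonyl (a number 3.6 percentage points higher from compound 2 to compound 4 (within the scatter)). Carboxy alone stands apart among the four groups shown at this position (a number 20.2 percentage points lower from compound 3 to compound 4 (beyond the scatter)), so a large ring of carbon entering here does not by itself shift the read-out beyond the scatter. Nothing given here accounts for why carboxy stands apart.

As far as these compounds go, whether an amine or a hydroxyl group at this carbon would stand with carboxy or with the other three groups remains open.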